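From Compound 2 to Compound 3: Exchanging One Aryl Group

The source may hold more compounds than are shown below. What is called first, only, known or untested is meant among the compounds shown, and "the series" means these compounds.

Measured so far:
compound 1, `O=C(Nc1ccc(Cl)cc1)Nc1ccc(Nc2ncnc3c2OCCN3)cc1`: 3070 nM
compound 2, `Cc1ccc(F)c(NC(=O)Nc2ccc(Nc3ncnc4c3OCCN4)cc2)c1`: 1470 nM

Both numbers come from an assay on isolated protein for inhibition of proto-oncogene tyrosine-protein kinase receptor Ret (Homo sapiens), read by 33P incorporation, with stated times of 15 min and 40 min; on this read-out lower numbers stand for stronger inhibition and higher numbers for weaker inhibition. Among the measured compounds shown here, compound 2 stands at the lower of the two numbers; its only neighbour is compound 1, and the step of a 2.1-fold lower number from compound 1 to compound 2 (0.32 log units; beyond the scatter) separates them. Compound 3, `Cc1cc(C)cc(NC(=O)Nc2ccc(Nc3ncnc4c3OCCN4)cc2)c1`, has not yet been measured. It differs from compound 2 by 3,5-dimethylphenyl in place of 2-fluoro-5-methylphenyl on an amide-type nitrogen. For the measured compounds named here, only one measured step touches this part of the molecule, the exchange of one aryl group for another that gave a 2.1-fold lower number from compound 1 to compound 2 (0.32 log units; beyond the scatter); it shows that such exchanges on this nitrogen move the number modestly. Going by the values given here, no measured pair shows what the loss of the fluorine contributes on its own. The step of a 1.1-fold higher number from compound 2 to compound 3 (0.04 log units; within the scatter) is therefore expected to be small, with no clear direction beyond the scatter. For compound 3 the estimate in this assay is 1600 nM, within a range from 500 nM to 5000 nM.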

Compound 3, half-maximal inhibitory concentration: 1070 nM
Compound 3: middle estimate off by 1.5-fold (0.17 log units), on the high side; the range from low to high includes it.
By their numbers in this assay, from the lowest: compounds 3 and 2 (each within the scatter of the next); then compound 1.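

Exchanging 2-fluoro-5-methylphenyl for 3,5-dimethylphenyl on this amide-type nitrogen gives a 1.4-fold lower number from compound 2 to compound 3 (0.14 log units; within the scatter), so in this assay compounds 2 and 3 cannot be told apart, even though the fluorine is gone. Measured against the 4-chlorophenyl group, the step is a 2.9-fold lower number from compound 1 to compound 3 (0.46 log units; beyond the scatter), which means that two different substituted phenyl groups now both give clearly lower numbers than compound 1. No measurement shown here offers an explanation for these differences between the aryl groups.

Still open, from the compounds shown here alone, is whether a phenyl group carrying a trifluoromethyl, an amine or a carboxylic acid on this nitrogen would shift the number much further. Going by these compounds, all three compounds also share the same core, so the effect of any change elsewhere in the molecule remains unknown.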